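The compounds below may be only part of what the source reports. "The series", "measured", "known", "first", "only" and "open" are said of these compounds alone.

Compound 3 `CNC(=O)C1CC=CC1n1cnc2c(NC3CC3)ncnc21` stands highest of the three numbers in an assay on cell membranes for displacement of a labelled ligand from adenosine receptor A1 (Rattus norvegicus), tested at 100 uM (a lower number here means less inhibition, a higher number more inhibition at the concentration tested (going by the name of the read-out)), where compound 3 gives 50%. In this assay compound 1 `CNC(=O)C1CCCC1n1cnc2c(N)ncnc21` gives 25%, and in this assay compound 2 `CNC(=O)C1CC=CC1n1cnc2c(N)ncnc21` gives 22%. Compound 4 `CNC(=O)C1CC=CC1n1cnc2c(NC3CCCC3)ncnc21` differs from compound 3 by cyclopentyl in place of cyclopropyl on a nitrogen on an aromatic ring. Among the compounds with values here, the one measured step that touches this nitrogen is a number 28 percentage points higher from compound 2 to compound 3 (beyond the scatter), a modest rise when a ring group replaced hydrogen there. Within the data shown here, no measured pair compares cyclopropyl with cyclopentyl, so the size of the next step is uncertain; a small further rise or no change beyond the scatter is expected, read as a number 5 percentage points higher from compound 3 to compound 4 (within the scatter). For compound 4 the estimate in this assay is 55%, expected to lie between 30% and 80%.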

Compound 4, a percentage reported as inhibition, at one concentration (the size of the read-out at that concentration, not a potency): < 10%
Compound 4: no number, only a limit; the forecaster's own chance of this, stated with the estimate: 0%; middle value at least 45 percentage points away from the limit.
By their numbers in this assay, from the lowest: compounds 2 and 1 (each within the scatter of the next); then compound 3. At a limit, below all of these: compound 4.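

In this assay, the group on this nitrogen matters beyond simply being a ring: cyclopentyl in place of cyclopropyl gives a number at least 40 percentage points lower from compound 3 to compound 4 (beyond the scatter). Cyclopentyl in place of hydrogen gives a number at least 12 percentage points lower from compound 2 to compound 4 (beyond the scatter), the opposite direction to the earlier rise with cyclopropyl, so that rise does not extend to every ring group here. The reading for compound 4 is a limit of the assay, not a number: the limit of < 10% in this assay, at which 1 of the 4 values shown sits.

The compounds shown leave open where cyclobutyl or an open chain such as isopropyl would fall on this nitrogen. They also leave open whether cyclopentyl would behave the same way on the core of compound 1.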